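Trimming the ester side chain of compound 3

The source may report more compounds than this note shows. Statements on the series, on what has been measured and on what is new or still open speak of the compounds shown alone.

In an ADME assay on HepG2 2.2.15 cells (Homo sapiens) for cytotoxicity (a lower number here means that less compound is tolerated, a higher number that more compound is tolerated), compound 1 (`CC(=O)OCC(=O)OCCc1c(-c2ccccc2Cl)c2cc(Cl)ccc2[nH]c1=O`) gives 100000 nM. Compound 2 (`O=C(OCCc1c(-c2ccccc2Cl)c2cc(Cl)ccc2[nH]c1=O)c1cccs1`) reaches only a limit of the assay, > 1700000 nM. Compound 3 (`O=C(/C=C/c1cccc(F)c1)OCCc1c(-c2ccccc2Cl)c2cc(Cl)ccc2[nH]c1=O`) also reaches only a limit, > 1600000 nM. Compound 3 therefore has no exact number, and it sits with compound 2 at the high end of the three values.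

Compound 4 (`C/C=C/C(=O)OCCc1c(-c2ccccc2Cl)c2cc(Cl)ccc2[nH]c1=O`) differs from compound 3 by methyl in place of 3-fluorophenyl on a double-bonded chain carbon bound to a double-bonded chain carbon, with methyl in place of 3-fluorophenyl, so that 2-(3-fluorophenyl)ethenyl becomes prop-1-en-1-yl. Within the data shown here, no measured step makes this exact change. The closest evidence is an at least 16-fold higher number from compound 1 to compound 3 (1.20 log units; beyond the scatter) and an at least 17-fold higher number from compound 1 to compound 2 (1.23 log units; beyond the scatter), both large and beyond the scatter, while a step that the two limits leave unreadable from compound 2 to compound 3. Compound 4 keeps the double-bonded chain of compound 3 and lacks the acetoxymethyl of compound 1, so little or no fall is expected, though a lower reading remains possible. The expected change is an at least 1.6-fold lower number from compound 3 to compound 4 (0.20 log units; that floor lies within the scatter). For compound 4 the estimated value is 1000000 nM, with an expected range of 150000 nM to 2500000 nM.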

Compound 4, half-maximal cytotoxic concentration: 30000 nM
For compound 4 the middle estimate is 33-fold (1.52 log units) above the measured one, outside the stated range (below it).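

In this assay, keeping the double-bonded chain does not by itself hold the high reading: methyl in place of 3-fluorophenyl gives an at least 53-fold lower number from compound 3 to compound 4 (1.72 log units; beyond the scatter). The thiophen-2-yl ester compares the same way, with an at least 56-fold lower number from compound 2 to compound 4 (1.75 log units; beyond the scatter), while the change from the acetoxymethyl ester gives a 3.3-fold lower number from compound 1 to compound 4 (0.52 log units; beyond the scatter), so among these four esters the two with a ring on the acyl side stand at limits and the two without one give exact, lower numbers. The step from compound 3 is only a floor because that compound reaches a limit of the assay: the limit of > 1600000 nM in this assay, at which 1 of the 4 values shown sits.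

The compounds shown leave open whether the ring itself or simply the size of the group tracks this reading. A plain phenyl in place of 3-fluorophenyl, or a longer saturated alkyl chain in place of methyl, would separate these two readings.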